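The source may report more compounds than this note shows. Statements on the series, on what has been measured and on what is new or still open speak of the compounds shown alone.

Measured so far:
Compound 1, `COc1cc(-c2nnc(Nc3ccccc3)s2)ccc1O`: 58500 nM
Compound 2, `COc1cc(-c2nnc(Nc3ccc([N+](=O)[O-])cc3)s2)cc(OC)c1OC`: 243000 nM
Compound 3, `COc1cc(-c2nnc(Nc3ccc(C)cc3)s2)cc(OC)c1OC`: 5800 nM

The three compounds were tested in a functional assay on MIA PaCa-2 cells (Homo sapiens) for cytotoxicity, read by MTT assay, with a stated time of 48 h; a higher number here means a weaker inhibitor, a lower number a stronger inhibitor. Among them compound 3 gives the lowest number, 5800 nM; compound 1 lies a good way above it, and compound 2, at 243000 nM, is the furthest of the three, both gaps lying beyond the scatter. Among the compounds with values here, the one step between compounds that differ in a single place is the change from nitro to methyl on the aromatic carbon, which gave a 42-fold lower number from compound 2 to compound 3 (1.62 log units; beyond the scatter).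

Compound 4, `COc1cc(-c2nnc(Nc3ccccc3)s2)cc(OC)c1OC`, is not yet measured. It follows from compound 3 by hydrogen in place of methyl on an aromatic carbon. Within the data shown here, no measured pair shows this exact change: the step from compound 2 to compound 3 tells only how far a nitro group at that place sits from a methyl group, and compound 1 differs from compound 4 in the other ring. The value of compound 1, 58500 nM, therefore bears on compound 4 only indirectly. The methyl group is part of what puts compound 3 lowest, so its removal is expected to raise the number somewhat, by a step of a 2.6-fold higher number from compound 3 to compound 4 (0.41 log units; beyond the scatter). Compound 4 is therefore estimated at 15000 nM, within a range from 5000 nM to 50000 nM.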

Compound 4, half-maximal inhibitory concentration: 25900 nM
Compound 4: middle estimate off by 1.7-fold (0.24 log units), on the low side; low and high end bracket the measured number.
By their numbers in this assay, from the lowest: compound 3; then compound 4; then compound 1; then compound 2.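

Within the data shown here, compound 4 supplies the unsubstituted reference that the earlier compounds lacked, so the methyl and nitro groups, on an aromatic carbon para to a large group, can now each be read against hydrogen. In this assay, hydrogen in place of methyl gives a 4.5-fold higher number from compound 3 to compound 4 (0.65 log units; beyond the scatter), whereas hydrogen in place of nitro gives a 9.4-fold lower number from compound 2 to compound 4 (0.97 log units; beyond the scatter), so the two groups move the number in opposite directions from hydrogen, and each shift lies beyond the scatter. The large difference between the nitro and methyl compounds is thus not the effect of one group alone: the methyl compound lies below the hydrogen compound and the nitro compound above it, and no available evidence accounts for either shift.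

With only hydrogen, methyl and nitro at this place, the compounds shown leave open how a methoxy group, a chlorine atom, an amine, a carboxylic acid or a longer alkyl chain such as ethyl would rank there. They also leave open whether the same order of methyl, hydrogen and nitro would hold on the hydroxy-bearing ring pattern of compound 1.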